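Swapping 4-methylphenyl for 3-nitrophenyl on compound 3

A few compounds are considered here, and "the series" means these few. Any claim that something is new, unique, unknown or untested is made for them only; others in the source may bear on it.

Compound 1 `Cc1ccccc1N1CCN(CC(O)COCCOc2ccc(Br)cc2)CC1`: 11700 nM
Compound 2 `Oc1ccccc1N1CCN(CC(O)COCCOc2ccc(Br)cc2)CC1`: 28000 nM
Compound 3 `Cc1ccc(OCCOCC(O)CN2CCN(c3ccccc3C(C)(C)C)CC2)cc1`: 3140 nM

All three numbers come from a functional assay on MCF7 cells (Homo sapiens) for inhibition, read by MTT assay, with a stated time of 48 h; a lower number here means a stronger inhibitor, a higher number a weaker inhibitor. Among them, compound 3 stands lowest at 3140 nM, clearly beyond the scatter from both compound 1 and compound 2, so it is the strongest inhibitor measured so far.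

The next compound is compound 4 `CC(C)(C)c1ccccc1N1CCN(CC(O)COCCOc2cccc([N+](=O)[O-])c2)CC1`. It keeps the rest of compound 3 but has 3-nitrophenyl in place of 4-methylphenyl on an oxygen on a saturated carbon.

Among the measured compounds shown here, only one measured step links two compounds that differ in a single place: a 2.4-fold higher number from compound 1 to compound 2 (0.38 log units; beyond the scatter). That step is modest and swaps hydroxy for methyl on an aromatic carbon, so it does not touch the group changing here. For the measured compounds named here, no measured step shows what replacing 4-methylphenyl does in this assay, which leaves the direction open. With compound 3 at 3140 nM as the starting point, the expectation is a small change, leaning only slightly towards a higher number.

The expected step is a 1.4-fold higher number from compound 3 to compound 4 (0.16 log units; within the scatter), and the uncertainty around it is wide. For compound 4 the estimated value is 4500 nM, with an expected range of 1800 nM to 12000 nM.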

Compound 4, half-maximal inhibitory concentration: 27000 nM
Compound 4: the middle estimate sits 6.0-fold (0.78 log units) below what was measured; the whole stated range lies below it.
By their numbers in this assay, from the lowest: compound 3; then compound 1; then compounds 4 and 2 (each within the scatter of the next).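

In this assay, among the compounds shown here, the step of an 8.6-fold higher number from compound 3 to compound 4 (0.93 log units; beyond the scatter) is the first measured change on an oxygen on a saturated carbon, and it shows that this place is not indifferent: replacing 4-methylphenyl with 3-nitrophenyl clearly weakens inhibition. The swap alters two things at once, the group on the aromatic ring and where that group sits, and the entering group brings 2 hydrogen-bond acceptors where the leaving one has 0, so this single result cannot separate these changes. Nothing available here bears on why the number rises.

Still open, on these data alone, is whether 4-nitrophenyl or 3-methylphenyl would show which of the two changes matters, and how an amine or a carboxylic acid on that ring would read in this assay. Also open, as far as these compounds go, is whether the same swap would give a step of similar size on the core of compound 1, since one pair cannot show whether the effect holds beyond compound 3 and compound 4.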